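This account rests on a few compounds, and the source may have more. Where it says the series, first, only, none or still open, it means among the compounds named here.

Measured compounds:
compound 1 `COC(=O)CN(Cc1cn([C@@H]2O[C@H](COC(C)=O)[C@@H](OC(C)=O)[C@H]2OC(C)=O)nn1)S(C)(=O)=O`: 250000 nM
compound 2 `COC(=O)C(C)(C)N(Cc1cn([C@@H]2O[C@H](COC(C)=O)[C@@H](OC(C)=O)[C@H]2OC(C)=O)nn1)S(C)(=O)=O`: 240000 nM
compound 3 `COC(=O)CN(Cc1cn([C@@H]2O[C@H](COC(C)=O)[C@@H](OC(C)=O)[C@H](OC(C)=O)[C@H]2OC(C)=O)nn1)S(C)(=O)=O`: a limit only, > 250000 nM

In a functional assay on MDA-MB-231 cells (Homo sapiens) for antiproliferative activity, read by XTT assay, with a stated time of 48 h (on this read-out higher numbers stand for weaker inhibition and lower numbers for stronger inhibition), compound 1 gives 250000 nM and compound 2 gives 240000 nM. The change 1-(methoxycarbonyl)-1-methylethyl in place of (methoxycarbonyl)methyl on a sulfonamide nitrogen therefore made a 1.0-fold lower number from compound 1 to compound 2 (0.02 log units; within the scatter). For compound 3 the assay reports only a limit, > 250000 nM, which is the limit of > 250000 nM in this assay, at which 1 of the 3 values shown sits. How the core of compound 3 differs from the core of compound 1 is not broken down here. Compound 4 `COC(=O)C(C)(C)N(Cc1cn([C@@H]2O[C@H](COC(C)=O)[C@@H](OC(C)=O)[C@H](OC(C)=O)[C@H]2OC(C)=O)nn1)S(C)(=O)=O` is the unmeasured partner of compound 3, carrying the same change as before: 1-(methoxycarbonyl)-1-methylethyl in place of (methoxycarbonyl)methyl on a sulfonamide nitrogen. The surroundings of the change are the same in both pairs, so it is the same change. For compound 4 a step that the limit leaves unreadable from compound 3 to compound 4 is expected. This expectation rests on the first pair, where a 1.0-fold lower number from compound 1 to compound 2 (0.02 log units; within the scatter) shows the change to have no effect. Compound 4 is thus estimated at 300000 nM, most likely again reported as a limit.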

Compound 4, half-maximal inhibitory concentration: 225000 nM
Compound 4: the middle estimate sits 1.3-fold (0.12 log units) above what was measured; the measured number falls inside the stated range.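

Carrying 1-(methoxycarbonyl)-1-methylethyl in place of (methoxycarbonyl)methyl over to the core of compound 3 gives an at least 1.1-fold lower number from compound 3 to compound 4 (0.04 log units; that floor lies within the scatter) in this assay. The value of compound 3, > 250000 nM, is a limit and not a number. The change therefore shows no sign of acting differently on the two cores, but this does not prove that it acts the same on both: the same change on two cores in this assay, a 1.0-fold lower number (0.02 log units; within the scatter) from compound 1 to compound 2 and an at least 1.1-fold lower number (0.04 log units; that floor lies within the scatter) from compound 3 to compound 4; the limit leaves it open whether they differ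

All the compounds shown keep the methoxycarbonyl group, so what a carboxylic acid or an amide would do in its place stays open. Going by these compounds, whether a longer chain in place of the 1-(methoxycarbonyl)-1-methylethyl group would give a different value in this assay also stays open.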